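The compounds below may be only part of what the source reports. "The series", "measured", "known", "first", "only" and "open" are said of these compounds alone.

Four close relatives of one shared core are compared here. Compound 1 `O=c1cc(/C=N\O)c2c(OCc3ccccc3)cc(OCc3ccccc3)cc2o1` and compound 2 `N/N=C\c1cc(=O)oc2cc(OCc3ccccc3)ccc12` are both reported in a functional assay, read by spectrophotometry, with a stated time of 1 h (on this read-out lower numbers stand for stronger inhibition and higher numbers for weaker inhibition), without a number behind their entries. Compound 1 is reported as "not active" (no number reported). Compound 2 is reported as "not active" (no number reported). Going by the values given here, compound 3 `O=c1cc(/C=N\c2ccc(O)cc2)c2c(OCc3ccccc3)cc(OCc3ccccc3)cc2o1` is the only member with a measured figure: in this assay compound 3 gives 107000 nM, which places it as a very weak inhibitor, yet it is the only point from which a number can be judged. Compound 4 `O=c1cc(/C=N\Nc2ccccc2)c2c(OCc3ccccc3)cc(OCc3ccccc3)cc2o1` has not been measured. It differs from compound 3 in a single spot: anilino in place of 4-hydroxyphenyl on a double-bonded nitrogen. Nothing in the measured set shows what such a swap does, so the two neighbours without a number, compound 1 and compound 2, are the only hint, and they point toward weakness rather than gain. The step from compound 3 to compound 4 is therefore expected to be small, a 1.4-fold higher number from compound 3 to compound 4 (0.15 log units; within the scatter), with a real chance that no number is returned at all. Compound 4 is estimated at 150000 nM, within a range from 50000 nM to 500000 nM.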

Compound 4, half-maximal inhibitory concentration: 401000 nM
Estimate against measurement, compound 4: 2.7-fold (0.43 log units) below; measured number inside the range.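

In this assay, going by these compounds alone, anilino in place of 4-hydroxyphenyl on a double-bonded nitrogen gives the first readable step at this position (a 3.7-fold higher number from compound 3 to compound 4 (0.57 log units; beyond the scatter)), a modest loss of inhibition that lies beyond the usual scatter. The two groups have the same counts of heavy atoms, hydrogen-bond donors and acceptors, and each holds one six-membered aromatic ring of carbon only, so the read-out responds here even to a swap that leaves these counts unchanged. Nothing measured here accounts for the loss.

Compound 1 and compound 2 carry no number, so steps involving them cannot be read. On these data alone, it remains open whether another group on this nitrogen, such as a carboxylic acid on the phenyl ring or a longer alkyl chain, would lower the number.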